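The source may hold more compounds than are shown below. What is called first, only, known or untested is meant among the compounds shown, and "the series" means these compounds.

Measured compounds in a functional assay on HT-29 cells (Homo sapiens) for antiproliferative activity, read by MTT assay, with a stated time of 24 h; a higher number here means a weaker inhibitor, a lower number a stronger inhibitor:
- compound 1, `COc1ccc(C(=O)/C=C/c2ccc(N(C)C)cc2)c2c1C=CC(C)(C)O2`, 1870 nM
- compound 2, `COc1ccc(C(=O)/C=C/c2cccc([N+](=O)[O-])c2)c2c1C=CC(C)(C)O2`, 4260 nM
- compound 3, `COc1ccc(C(=O)/C=C/c2cccc(C(F)(F)F)c2)c2c1C=CC(C)(C)O2`, 9050 nM

Compound 2 sits second highest of these three numbers: the move to compound 3 gave a 2.1-fold higher number from compound 2 to compound 3 (0.33 log units; beyond the scatter), while compound 1 lies a step lower, since a 2.3-fold higher number from compound 1 to compound 2 (0.36 log units; beyond the scatter). Compound 4, `COc1ccc(C(=O)/C=C/c2ccc(O)cc2)c2c1C=CC(C)(C)O2`, has not yet been tested; it differs from compound 2 in one place: 4-hydroxyphenyl in place of 3-nitrophenyl on a double-bonded chain carbon bound to a double-bonded chain carbon. Within the data shown here, two measured steps bear on this exchange. The step from compound 1 to compound 2 replaced another ring bearing a 4-substituent with the 3-nitrophenyl, and the step from compound 2 to compound 3 changed only the group on that ring; both were modest. The new change partly reverses the first, so a modest drop toward compound 1 is expected in this assay, a 1.7-fold lower number from compound 2 to compound 4 (0.23 log units; within the scatter). Compound 4 is therefore estimated at 2500 nM, with a range from 1200 nM to 5500 nM.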

Compound 4, half-maximal inhibitory concentration: > 10000 nM
Compound 4: a limit, no number; the forecaster's own chance of this, stated with the estimate: 5%; middle value at least 4.0-fold (0.60 log units) from the limit.
By their numbers in this assay, from the lowest: compound 1; then compound 2; then compound 3. At a limit, above all of these: compound 4.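

Compound 4 gives a limit, not a number: the limit of > 10000 nM in this assay, at which 1 of the 4 values shown sits. At this position, a substituent at the 4-position does not by itself preserve activity: hydroxy in place of dimethylamino gave an at least 5.3-fold higher number from compound 1 to compound 4 (0.72 log units; beyond the scatter). Among these compounds, the exchange from the 3-nitrophenyl group was also far from neutral, giving an at least 2.3-fold higher number from compound 2 to compound 4 (0.37 log units; beyond the scatter), so the group on this ring matters more than the earlier steps showed.

The compounds shown leave open whether the loss follows the hydroxy group itself or its place on the ring. A 3-hydroxyphenyl or 4-methoxyphenyl group would help separate these two readings.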